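A few compounds are considered here, and "the series" means these few. Any claim that something is new, unique, unknown or untested is made for them only; others in the source may bear on it.

Compound 1 `Cc1cccc(Nc2nccc(-c3cccs3)n2)c1` gives 300 nM in a functional assay for inhibition, with Homo sapiens as the target; on this read-out lower numbers stand for stronger inhibition and higher numbers for weaker inhibition. Compound 3 `Cc1cccc(Nc2nccc(-c3ccncc3)n2)c1` gives 8800 nM and compound 2 `COc1ccc(Nc2nccc(-c3ccncc3)n2)cc1` gives 4200 nM in this assay; the difference between the two cores of compound 2 and compound 3 is not broken down here. The change thiophen-2-yl in place of pyridin-4-yl on an aromatic carbon brought a 29-fold lower number from compound 3 to compound 1 (1.47 log units; beyond the scatter). The same kind of change, (thiophen-2-yl in place of pyridin-4-yl on an aromatic carbon), leads from compound 2 to compound 4 `COc1ccc(Nc2nccc(-c3cccs3)n2)cc1`, which is not yet measured; the two places differ only in that the group meta to the place counts 9 heavy atoms in compound 2 against 8 in compound 3. Since the earlier step of a 29-fold lower number from compound 3 to compound 1 (1.47 log units; beyond the scatter) was large, a similar step is expected, a 21-fold lower number from compound 2 to compound 4 (1.32 log units; beyond the scatter), resting on that single instance. Compound 4 is therefore estimated at 200 nM, within a range of 60 nM to 900 nM.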

Compound 4, half-maximal inhibitory concentration: 3900 nM
Beside the measured number, compound 4's estimate is 20-fold (1.29 log units) below it; measured number above the stated range.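

In this assay, thiophen-2-yl in place of pyridin-4-yl brought only a 1.1-fold lower number from compound 2 to compound 4 (0.03 log units; within the scatter), so the change does not carry over between cores as a fixed step. The two steps differ clearly: the same change on two cores in this assay, a 29-fold lower number (1.47 log units; beyond the scatter) from compound 3 to compound 1 and a 1.1-fold lower number (0.03 log units; within the scatter) from compound 2 to compound 4, 27-fold (1.44 log units) apart, beyond the scatter of two such steps. This shows that the size of the step depends on the core in these two pairs, but it does not show which feature of the cores sets the gap, and two pairs give no rule for a further core.

Going by these compounds, it remains open whether a further core would follow either step. Also open, on these data alone, is how the two cores would respond to an amine or a carboxylic acid at this place.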